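This account rests on a few compounds, and the source may have more. Where it says the series, first, only, none or still open, it means among the compounds named here.

Compound 1, `O=C(Nc1ccnnc1)c1cc(N2CCCCC2)ccc1OCc1ccccc1`, gives 25.1 nM in an assay on Sf9 cells for inhibition of Leucine-rich repeat serine/threonine-protein kinase 2 (Homo sapiens), read by TR-FRET, with stated times of 30 min and 2 h; on this read-out higher numbers stand for weaker inhibition and lower numbers for stronger inhibition.
Compound 2, `O=C(Nc1ccnnc1)c1cc(N2CCCC2)ccc1OCc1ccccc1`, gives 20 nM in this assay.
Compound 3, `O=C(Nc1ccnnc1)c1cc(N2CCNCC2)ccc1OCc1ccccc1`, gives 15.9 nM in this assay.

Compound 1 stands highest of the three numbers, but only by small margins: the step to compound 2 is a 1.3-fold lower number from compound 1 to compound 2 (0.10 log units; within the scatter) and the step to compound 3 is a 1.6-fold lower number from compound 1 to compound 3 (0.20 log units; within the scatter), both within the scatter, as is the step between those two, a 1.3-fold lower number from compound 2 to compound 3 (0.10 log units; within the scatter). None of the three compounds can be called more or less potent than the others.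

Compound 4, `O=C(Nc1ccnnc1)c1cc(N2CCC(CO)CC2)ccc1OCc1ccccc1`, differs from compound 1 in one place: hydroxymethyl in place of hydrogen on a saturated ring carbon. The steps measured so far change the ring itself, swapping piperidin-1-yl for pyrrolidin-1-yl or piperazin-1-yl, and none of them adds a group to a saturated ring carbon, so they bear on the new step only indirectly. What they do show is that varying this position of the shared core has left this assay unchanged within the scatter each time. On that basis compound 4 is expected to show a step of a 1.3-fold lower number from compound 1 to compound 4 (0.10 log units; within the scatter), that is, no change beyond the scatter. The estimate for compound 4 in this assay is 20 nM, with a range from 8 nM to 50 nM.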

Compound 4, half-maximal inhibitory concentration: 20 nM
The estimate for compound 4 equals the measured number at the digits printed; measured number inside the range.
By their numbers in this assay, from the lowest: compounds 3, 2, 4 and 1 (each within the scatter of the next).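

Adding a group to a saturated ring carbon of the piperidin-1-yl ring, rather than exchanging the ring itself, is a kind of change the earlier compounds did not cover, and in this assay hydroxymethyl at this place, three ring bonds from the ring nitrogen, gives a 1.3-fold lower number from compound 1 to compound 4 (0.10 log units; within the scatter) for this step. Compared with the other two rings, the 4-(hydroxymethyl)piperidin-1-yl group gives a 1.3-fold higher number from compound 3 to compound 4 (0.10 log units; within the scatter) and no change at the digits printed from compound 2 to compound 4 (within the scatter) as its two remaining steps. This ring carbon of compound 1 therefore accepts a group with a hydrogen-bond donor and a hydrogen-bond acceptor with no step beyond the scatter in this assay, and no order can be drawn among the four compounds. Nothing available explains this result.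

The compounds shown leave open whether an aminomethyl group, a carboxylic acid or a longer chain such as 2-hydroxyethyl on the same ring carbon would also remain within the scatter of compound 1. They also leave open what hydroxymethyl would do on another saturated ring carbon of the piperidin-1-yl ring.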